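The source may hold more compounds than are shown below. What is called first, only, known or untested is meant among the compounds shown, and "the series" means these compounds.

Measured in an ADME assay on microsomes from liver (Mus musculus) for metabolic stability, read by LC-MS, with a stated time of 1 h, tested at 5 uM; on this read-out lower numbers stand for a less stable compound and higher numbers for a more stable compound:
- compound 1 `Cc1nc(-c2ccccc2)c(C(=O)N2CCN(c3cccc(C)c3C)CC2)o1`: 83.6%
- compound 2 `Cc1ccc(C)c(N2CCN(C(=O)c3oc(C)nc3-c3ccccc3)CC2)c1`: 1.4%
- compound 3 `Cc1cc(C)cc(N2CCN(C(=O)c3oc(C)nc3-c3ccccc3)CC2)c1`: 12%

Compound 3 stands second of the three, much closer to the low end than to the high end. Its position is set by two steps: a number 10.6 percentage points higher from compound 2 to compound 3 (beyond the scatter), which is modest, and a number 71.6 percentage points lower from compound 1 to compound 3 (beyond the scatter), which is large.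

Compound 4 `Cc1nc(-c2ccccc2)c(C(=O)N2CCN(c3cc(Cl)cc(Cl)c3)CC2)o1` differs from compound 3 in one place: 3,5-dichlorophenyl in place of 3,5-dimethylphenyl on an amine nitrogen in a ring. Here 3,5-dichlorophenyl takes the place of 3,5-dimethylphenyl on an amine nitrogen in a ring.

Going by the values given here, no measured step makes this exchange, so the evidence is only indirect. The large steps of a number 82.2 percentage points lower from compound 1 to compound 2 (beyond the scatter) and a number 71.6 percentage points lower from compound 1 to compound 3 (beyond the scatter) show that, in this small set, changing the group on that nitrogen can move this assay a long way. Compound 3, at 12%, has little room to fall, so a moderate rise is expected, though with low confidence. The expected change is a number 18 percentage points higher from compound 3 to compound 4 (beyond the scatter). For compound 4 the estimated value is 30%, with an expected range from 8% to 65%.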

Compound 4, percent of the compound remaining: 43.4%
Estimate against measurement, compound 4: 13.4 percentage points below; measured number inside the range.
By their numbers in this assay, from the lowest: compound 2; then compound 3; then compound 4; then compound 1.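

With 3,5-dichlorophenyl in place of 3,5-dimethylphenyl, the exchange of methyl groups for chlorine gives a number 31.4 percentage points higher from compound 3 to compound 4 (beyond the scatter) in this assay, so the atoms on this aryl group matter as well as where they sit. The dichloro compound also stands clear of the 2,5-dimethylphenyl compound, with a number 42 percentage points higher from compound 2 to compound 4 (beyond the scatter), yet it does not match the 2,3-dimethylphenyl compound, with a number 40.2 percentage points lower from compound 1 to compound 4 (beyond the scatter), so compound 4 lands between the low pair and compound 1. Nothing measured here accounts for these differences.

The compounds shown leave open whether 2,3-dichlorophenyl on the same nitrogen would reach the level of compound 1. They also leave open whether 3,5-difluorophenyl or 3,5-dimethoxyphenyl would follow the dichloro compound or the dimethyl compound.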